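Amide variation on the shared core of compound 1

The compounds below may be only part of what the source reports. "The series", "measured", "known", "first", "only" and "open" are said of these compounds alone.

In a functional assay on the whole organism (strain Wistar) for inhibition, with Rattus norvegicus as the target, read by paw edema, with stated times of 60 min and 6 h, at a dose of 100 mg/kg by the oral route (a lower number here means less inhibition, a higher number more inhibition at the dose given (going by the name of the read-out)), compound 1 `COc1cc2c(cc1OC)C(CC(=O)O)CC2` gives 20.4%, the lowest of the three numbers in hand. Compound 2 `CCCNC(=O)CC1CCc2cc(OC)c(OC)cc21` gives 22.2% in this assay, and compound 3 `CCCCCNC(=O)CC1CCc2cc(OC)c(OC)cc21` gives 35.2%. The nearest neighbour of compound 1 is compound 2, with a number 1.8 percentage points higher from compound 1 to compound 2 (within the scatter); the furthest is compound 3, with a number 14.8 percentage points higher from compound 1 to compound 3 (beyond the scatter). Between the two amides the step of a number 13 percentage points higher from compound 2 to compound 3 (beyond the scatter) separates them.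

Compound 4 `COc1cc2c(cc1OC)C(CC(=O)NC1CCCCC1)CC2` is not yet measured. Its change from compound 1 is cyclohexylamino in place of hydroxy on a carbonyl carbon. Within the data shown here, the steps that bear on it are the two amide-forming steps from the acid: a number 1.8 percentage points higher from compound 1 to compound 2 (within the scatter) fell within the scatter, while a number 14.8 percentage points higher from compound 1 to compound 3 (beyond the scatter) was beyond it and modest in size. The cyclohexylamino group, by the count given above, is the largest of the three amine groups, and compound 3 with its pentylamino group gives 35.2%, so a step in this assay of the same kind is expected, upward and modest, rather than none at all.

Compound 4 is therefore expected to give 34% in this assay, within a range of 20% to 48%. This estimate for compound 4 means a step of a number 13.6 percentage points higher from compound 1 to compound 4 (beyond the scatter).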

Compound 4, a percentage reported as inhibition, in the whole organism at one dose (the size of the read-out at that dose, not a potency): 48.2%
Beside the measured number, compound 4's estimate is 14.2 percentage points below it, and the stated range ends below it.
By their numbers in this assay, from the lowest: compounds 1 and 2 (each within the scatter of the next); then compound 3; then compound 4.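

On the carbonyl carbon of the shared core, cyclohexylamino in place of hydroxy gives the largest step from the acid in this assay (a number 27.8 percentage points higher from compound 1 to compound 4 (beyond the scatter)), and compound 4 is the only amide so far whose number stands beyond the scatter of both other amides. The change on the amide-type nitrogen reads clearly in both comparisons, with cyclohexyl in place of pentyl (a number 13 percentage points higher from compound 3 to compound 4 (beyond the scatter)) and cyclohexyl in place of propyl (a number 26 percentage points higher from compound 2 to compound 4 (beyond the scatter)), so at this position a six-membered ring of carbon only on the nitrogen carries the number past both open chains shown. Nothing in hand gives a reason for these steps.

Still open, on these data alone, is whether the ring itself matters or the number would also rise with a longer chain such as hexyl or octyl on the nitrogen, and whether a smaller ring such as cyclopentyl or an aromatic group such as benzyl would hold it. A tertiary amide such as the piperidine amide, which lacks the amide hydrogen, would show whether that hydrogen is needed to keep the step.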